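From 4-methoxyphenyl to 3-methoxyphenyl at the assay limit

The compounds below may be only part of what the source reports. "The series", "measured", "known", "first", "only" and "open" are said of these compounds alone.

Compound 1 `CN(C)c1ccc(C=C2C(=O)N(c3ccc(Cl)cc3)N(c3ccc(Cl)cc3)C2=O)cc1`: > 128000 nM
Compound 2 `COc1ccc(C=C2C(=O)N(c3ccc(Cl)cc3)N(c3ccc(Cl)cc3)C2=O)cc1`: > 128000 nM

In a functional assay on SMMC-7721 cells (Homo sapiens) for cytotoxicity, read by MTT assay, with a stated time of 72 h (on this read-out lower numbers stand for stronger inhibition and higher numbers for weaker inhibition), compound 2 gives > 128000 nM, which is a limit and not a number. Compound 1 gives > 128000 nM, also a limit. Both values rest at the same point: the limit of > 128000 nM in this assay, at which 2 of the 2 values shown sit. Within the data shown here, the only measured step, a step that the two limits leave unreadable from compound 1 to compound 2, has no readable size and shows no direction.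

Compound 3 `COc1cccc(C=C2C(=O)N(c3ccc(Cl)cc3)N(c3ccc(Cl)cc3)C2=O)c1` carries 3-methoxyphenyl in place of 4-methoxyphenyl on a double-bonded chain carbon bound to a double-bonded ring carbon. Among the measured compounds shown here, with no sized step to draw on, no change beyond the scatter is expected in this assay, and a report of a limit alone is the likeliest outcome. The estimated step is a number no higher from compound 2 to compound 3 (the limit leaves the size open), with no direction expected. For compound 3 the estimated value is 128000 nM, with 64000 nM to 256000 nM as the expected range.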

Compound 3, half-maximal inhibitory concentration: 30200 nM
The estimate for compound 3 lay 4.2-fold (0.63 log units) above the measured number; measured number below the stated range.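

In this assay, among these compounds, 3-methoxyphenyl in place of 4-methoxyphenyl on a double-bonded chain carbon bound to a double-bonded ring carbon gives an at least 4.2-fold lower number from compound 2 to compound 3 (0.62 log units; beyond the scatter), the first step with a readable direction, and one made with the same atoms joined differently. Against the dimethylamino compound, 3-methoxyphenyl in place of 4-(dimethylamino)phenyl at that place gives an at least 4.2-fold lower number from compound 1 to compound 3 (0.62 log units; beyond the scatter), whereas the step between compound 1 and compound 2 cannot be read. Compound 3 is the only one of the three with a measured number rather than a limit, and the others remain at: the limit of > 128000 nM in this assay, at which 2 of the 3 values shown sit.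

As far as these compounds go, the full size of both readable steps stays open, since each starts from a limit. Also open, from the compounds shown here alone, is whether a hydroxyl or an amine in place of the methoxy of compound 3 would keep a measurable number in this assay.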